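Replacing the Benzyl Group of Compound 3

A few compounds are considered here, and "the series" means these few. Any claim that something is new, unique, unknown or untested is made for them only; others in the source may bear on it.

Compound 3 `NC(=O)c1c(NC(=O)c2ccccc2Cl)sc2c1CCN(Cc1cc(Cl)cc(Cl)c1)C2` gives 15800 nM in a functional assay on HL-60 cells (Homo sapiens) for antiproliferative activity, with a stated time of 24 h (a higher number here means a weaker inhibitor, a lower number a stronger inhibitor), the highest of the two numbers recorded here. Compound 2 `NC(=O)c1c(NC(=O)c2ccccc2Cl)sc2c1CCN(Cc1ccc(Cl)cc1Cl)C2` gives 8010 nM, and the step of a 2.0-fold higher number from compound 2 to compound 3 (0.30 log units; within the scatter) lies within the scatter. In this assay compound 1 `Cc1ccccc1CN1CCc2c(sc(NC(=O)c3ccccc3Cl)c2C(N)=O)C1` gives > 50000 nM, which is a limit of the assay and not a number. For compound 1 only a limit is known, namely (the limit of > 50000 nM in this assay, at which 1 of the 3 values shown sits). Compound 4 `NC(=O)c1c(NC(=O)c2ccccc2Cl)sc2c1CCN(C(=S)Nc1ccccc1Br)C2` differs from compound 3 in a group of 10 heavy atoms (7 carbon, 1 nitrogen, 1 sulfur, 1 bromine; one six-membered aromatic ring of carbon only) in place of a group of 9 heavy atoms (7 carbon, 2 chlorine; one six-membered aromatic ring of carbon only), on an amine nitrogen in a ring. The measured steps of an at least 6.2-fold lower number from compound 1 to compound 2 (0.79 log units; beyond the scatter) and an at least 3.1-fold lower number from compound 1 to compound 3 (0.50 log units; beyond the scatter) exchange only the aryl ring on the same benzyl carbon, so none of the recorded steps covers a change of this kind, and the expected step of a 1.1-fold lower number from compound 3 to compound 4 (0.02 log units; within the scatter) is therefore set close to none, with wide uncertainty. Compound 4 is estimated at 15000 nM, with a range from 3500 nM to 60000 nM.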

Compound 4, half-maximal inhibitory concentration: 9090 nM
Compound 4: middle estimate off by 1.7-fold (0.22 log units), on the high side; the range from low to high includes it.
By their numbers in this assay, from the lowest: compounds 2, 4 and 3 (each within the scatter of the next). At a limit, above all of these: compound 1.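

On the amine nitrogen in a ring, this assay now shows that a group without the benzyl carbon can stand where the dichlorobenzyl groups stood, with no change beyond the scatter: a 1.7-fold lower number from compound 3 to compound 4 (0.24 log units; within the scatter) and a 1.1-fold higher number from compound 2 to compound 4 (0.05 log units; within the scatter). The third step, an at least 5.5-fold lower number from compound 1 to compound 4 (0.74 log units; beyond the scatter), is read against a limit and not a number: the limit of > 50000 nM in this assay, at which 1 of the 4 values shown sits.

On these data alone, what an acetyl group or a longer alkyl chain on this nitrogen would give stays open. As far as these compounds go, the share of the bromine in the value of compound 4 also stays open.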